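Propyl in place of dimethylamino: compound 3

A few compounds are considered here, and "the series" means these few. Any claim that something is new, unique, unknown or untested is made for them only; others in the source may bear on it.

Values in a functional assay on the whole organism for antagonist activity, with Mus musculus as the target; a higher number here means that more compound is needed for the effect, a lower number that less compound is needed:
- compound 1 `CC(NC(=O)CN)C(=O)N(C)c1ccc(Cl)cc1C(=O)c1ccccc1Cl`: 0.47 mg/kg
- compound 2 `CN(C)CC(=O)NCC(=O)N(C)c1ccc(Cl)cc1C(=O)c1ccccc1Cl`: 2.6 mg/kg

Compound 2 holds the higher of the two numbers. Compound 3 `CCCCC(=O)NCC(=O)N(C)c1ccc(Cl)cc1C(=O)c1ccccc1Cl` has propyl in place of dimethylamino on a saturated chain carbon bound to a carbonyl carbon. For the measured compounds named here, one measured step bears on this change, a 5.5-fold higher number from compound 1 to compound 2 (0.74 log units; beyond the scatter), and it does not swap this group alone. Going by the values given here, no measured pair isolates the change. A modest step towards a higher number in this assay is therefore expected, of similar size and with wide uncertainty. The estimated step is a 3.1-fold higher number from compound 2 to compound 3 (0.49 log units; beyond the scatter). For compound 3 the expected value is 8 mg/kg, with an estimated range of 2 mg/kg to 35 mg/kg.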

Compound 3, dose for half-maximal effect: 1.3 mg/kg
The estimate for compound 3 lay 6.2-fold (0.79 log units) above the measured number; measured number outside the range, below it.
By their numbers in this assay, from the lowest: compound 1; then compounds 3 and 2 (each within the scatter of the next).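

In this assay, propyl in place of dimethylamino gives a 2.0-fold lower number from compound 2 to compound 3 (0.30 log units; within the scatter), so at this place a group without nitrogen reads the same as dimethylamino. Moving to the butylcarbonyl side chain gives a 2.8-fold higher number from compound 1 to compound 3 (0.44 log units; beyond the scatter), which leaves compound 1 with the lowest number of the three. No available measurement accounts for this result.

Still open, as far as these compounds go, is whether the lower number of compound 1 follows from its aminomethyl group or from the methyl of its ethyl linker, since the two change together. Also open, from the compounds shown here alone, is how a carboxylic acid or a longer alkyl chain would read at this place.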